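A few compounds are considered here, and "the series" means these few. Any claim that something is new, unique, unknown or untested is made for them only; others in the source may bear on it.

Going by the values given here, in a functional assay on BMEC cells (Bos taurus) for antiproliferative activity (a higher number here means a weaker inhibitor, a lower number a stronger inhibitor), compound 1 `COc1cc(/C=C/Cc2cc(O)c3ccsc3c2)cc(OC)c1OC` gives 38700 nM and so holds the higher of the two numbers measured so far. Among the compounds with values here, compound 2 `COc1cc(/C=C/Cc2cc(O)c3cc(C)sc3c2)cc(OC)c1OC` gives 840 nM and the one measured step, a 46-fold lower number from compound 1 to compound 2 (1.66 log units; beyond the scatter), puts a methyl in place of hydrogen on an aromatic carbon. Compound 3 `COc1cc(/C=C/Cc2cc(OC)c3ccsc3c2)cc(OC)c1OC` has not yet been measured. It differs from compound 1 by methyl in place of hydrogen on an oxygen on an aromatic ring on the core, which is methyl in place of hydrogen on an oxygen on an aromatic ring, or hydroxy to methoxy. Within the data shown here, no measured step covers this change. The large step to compound 2 shows only that one added methyl can shift the number strongly at another place. A modest move to a lower number is therefore expected, estimated as a 1.9-fold lower number from compound 1 to compound 3 (0.29 log units; within the scatter) with wide uncertainty. For compound 3 the estimated value is 20000 nM within an expected range from 3000 nM to 100000 nM in this measure.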

Compound 3, half-maximal inhibitory concentration: 53000 nM
Compound 3: the middle estimate sits 2.7-fold (0.42 log units) below what was measured; the range from low to high includes it.
By their numbers in this assay, from the lowest: compound 2; then compounds 1 and 3 (each within the scatter of the next).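

Replacing the hydroxy with methoxy on the core gives a 1.4-fold higher number from compound 1 to compound 3 (0.14 log units; within the scatter) in this assay, so at this oxygen on an aromatic ring, a hydrogen can give way to a methyl with no change beyond the scatter. The earlier step, a 46-fold lower number from compound 1 to compound 2 (1.66 log units; beyond the scatter), put the same single methyl on an aromatic carbon and went beyond the scatter, so among these compounds the size of a methyl step depends on where the methyl stands. No measurement shown here gives a reason for this difference between the two places.

The compounds shown leave open whether hydroxy to methoxy would stay within the scatter on the core of compound 2, which carries the methyl. They also leave open what a longer chain such as ethoxy, or an amine in place of the hydroxy, would do at this oxygen-bearing place.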